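The source may report more compounds than this note shows. Statements on the series, on what has been measured and on what is new or still open speak of the compounds shown alone.

Of the compounds shown here, three share one core and have been measured in an assay on HEK293 cells for displacement of a labelled ligand from metabotropic glutamate receptor 5 (Homo sapiens), with a stated time of 2 h; a lower number here means a stronger inhibitor, a higher number a weaker inhibitor. Compound 1 `CC(C)N1CCc2nc(C#Cc3ccccc3)ccc2C1=O` gives 1280 nM, compound 2 `CC(C)N1CCc2nc(C#Cc3cccc(Cl)c3)ccc2C1=O` gives 100 nM, and compound 3 `O=C1c2ccc(C#Cc3ccccc3)nc2CCN1C1CCCC1` gives 890 nM. The number for compound 3 lies within the usual scatter of that for compound 1, as the step of a 1.4-fold lower number from compound 1 to compound 3 (0.16 log units; within the scatter) shows, while the step of a 13-fold lower number from compound 1 to compound 2 (1.11 log units; beyond the scatter) is large and sets compound 2 apart from both. Compound 4 `O=C1c2ccc(C#Cc3cccnc3)nc2CCN1C1CCCC1` differs from compound 3 by pyridin-3-yl in place of phenyl on a triple-bonded carbon. Neither measured step touches this change: one alters the group on the nitrogen in the ring, the other adds chloro to the phenyl. With no direct guide, the step of a 1.5-fold lower number from compound 3 to compound 4 (0.17 log units; within the scatter) is expected to be small. Compound 4 is therefore estimated at 600 nM, probably between 200 nM and 2000 nM.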

Compound 4, inhibition constant: > 32000 nM
Compound 4 ended at the assay's limit; the forecaster's own chance of this, stated with the estimate: 5%; middle value at least 53-fold (1.72 log units) from the limit.
By their numbers in this assay, from the lowest: compound 2; then compounds 3 and 1 (each within the scatter of the next). At a limit, above all of these: compound 4.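

Replacing phenyl with pyridin-3-yl on the triple-bonded carbon gives an at least 35-fold higher number from compound 3 to compound 4 (1.55 log units; beyond the scatter), a large loss from a swap that leaves the heavy-atom count unchanged. This position is therefore highly sensitive, whereas changing the group on the nitrogen gave only a 1.4-fold lower number from compound 1 to compound 3 (0.16 log units; within the scatter). The value for compound 4 is a limit of the assay, not a number: the limit of > 32000 nM in this assay, at which 1 of the 4 values shown sits.

As far as these compounds go, it remains open whether pyridin-4-yl would give the same loss as pyridin-3-yl. From the compounds shown here alone, whether a chloro group on the pyridin-3-yl would bring the number back down also remains unknown.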